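Ester series on a shared core: chain length and cytotoxicity

The source may report more compounds than this note shows. Statements on the series, on what has been measured and on what is new or still open speak of the compounds shown alone.

Compound 1 `CCCCCCCCOC(=O)C(O)Cn1cnc2c(N)ncnc21` carries an octyl ester on the shared core, and in a functional assay on Vero cells (Chlorocebus sabaeus) for cytotoxicity (on this read-out higher numbers stand for lower toxicity in this test and lower numbers for higher toxicity in this test), compound 1 gives 200 ug/mL. Compound 2 `COC(=O)C(O)Cn1cnc2c(N)ncnc21` is the methyl ester; in this assay compound 2 reaches only a limit of the test, > 400 ug/mL. Compound 3 `Nc1ncnc2c1ncn2CC(O)C(=O)OCc1ccco1` is the furan-2-ylmethyl ester, and in this assay compound 3 gives 40 ug/mL.

Compound 4 `CCC(C)OC(=O)C(O)Cn1cnc2c(N)ncnc21` is the unmeasured member. It differs from compound 1 as follows: sec-butyl in place of octyl on an oxygen next to a carbonyl group.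

Among the compounds with values here, two measured steps bear on this change. From compound 1 to compound 2, removing most of the chain, the number moved an at least 2.0-fold higher number from compound 1 to compound 2 (0.30 log units; that floor lies within the scatter). From compound 1 to compound 3, replacing the chain end with a ring, the number moved a 5.0-fold lower number from compound 1 to compound 3 (0.70 log units; beyond the scatter). Compound 4 keeps a plain saturated chain, shorter than in compound 1 and longer than in compound 2, so a step toward a higher number, or none beyond the scatter, is expected in this assay.

For compound 4 the expected value in this assay is 300 ug/mL, within 150 ug/mL to 600 ug/mL. That estimate for compound 4 corresponds to an expected step of a 1.5-fold higher number from compound 1 to compound 4 (0.18 log units; within the scatter) in this assay.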

Compound 4, minimum cytotoxic concentration: > 400 ug/mL
Compound 4 gave a limit, no number (the forecaster's own chance of this, stated with the estimate: 30%); middle value at least 1.3-fold (0.12 log units) from the limit.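

In this assay, going by these compounds, sec-butyl in place of octyl gives an at least 2.0-fold higher number from compound 1 to compound 4 (0.30 log units; that floor lies within the scatter), a floor that is itself within the scatter, so the shortened, branched ester shows no readable gain over compound 1, while its true number remains unknown. Sec-butyl in place of (furan-2-yl)methyl gives an at least 10-fold higher number from compound 3 to compound 4 (1.00 log units; beyond the scatter), so the low number of compound 3 now stands apart from a branched saturated ester as well as from the methyl and octyl esters. The methyl and sec-butyl esters cannot be ordered, and no step between compound 2 and compound 4 can be read, because both stand at the same limit of the test: the limit of > 400 ug/mL in this assay, at which 2 of the 4 values shown sit.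

Still open, on these data alone, is whether branching matters at all, which a straight-chain butyl ester would address, and where a measurable number first appears between sec-butyl and octyl or with a longer chain such as dodecyl. Also open, as far as these compounds go, is whether the low number of compound 3 follows the furan ring specifically or any ring on this ester, a question on which a benzyl ester would bear.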